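The source may hold more compounds than are shown below. What is called first, only, known or untested is meant among the compounds shown, and "the series" means these compounds.

The series is read in a physicochemical assay for lipophilicity, read by HPLC; on this read-out higher numbers stand for higher lipophilicity and lower numbers for lower lipophilicity. Among the measured compounds shown here, compound 1 (`Cc1ccsc1C(=CCCN(C)C(CCN)C(=O)NCc1ccc(Cl)cc1)c1sccc1C`) gives 5.85, the lower of the two numbers so far, and compound 2 (`Cc1ccsc1C(=CCCN(C)C(CCN)C(=O)NCc1ccc(F)cc1)c1sccc1C`) gives 6.45. Compound 3 (`Cc1ccsc1C(=CCCN(C)C(CO)C(=O)NCc1ccc(Cl)cc1)c1sccc1C`) is not yet measured and differs from compound 1 in one place: hydroxy in place of aminomethyl on a saturated chain carbon, two bonds along the chain from an amine nitrogen and a carbonyl carbon. In short, it has hydroxy in place of aminomethyl on a saturated chain carbon, two bonds along the chain from an amine nitrogen and a carbonyl carbon. For the measured compounds named here, the only measured step, a number 0.60 log units higher from compound 1 to compound 2 (beyond the scatter), is fluoro in place of chloro on an aromatic carbon. It does not test the present change and serves only as a guide to the size of a single replacement in this series. On that guide, a modest rise is expected, though its direction is uncertain. The estimated step is a number 0.35 log units higher from compound 1 to compound 3 (beyond the scatter). Compound 3 is estimated at 6.2, with an expected range of 5.6 to 6.8.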

Compound 3, partition coefficient: 6.47
The estimate for compound 3 lay 0.27 log units below the measured number, and the stated range covers the measured number.
By their numbers in this assay, from the lowest: compound 1; then compounds 2 and 3 (each within the scatter of the next).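

In this assay, hydroxy in place of aminomethyl on this saturated chain carbon gives a number 0.62 log units higher from compound 1 to compound 3 (beyond the scatter), so the read-out responds to a change at this position as well as to the aromatic replacement seen earlier. The step comes with one heavy atom fewer and oxygen in place of nitrogen, while the printed counts of hydrogen-bond donors and acceptors stay the same and neither group carries a net charge. No available measurement bears on what lies behind this step.

With a single replacement at this position, the effects of the loss of carbon and the exchange of nitrogen for oxygen cannot be separated. On these data alone, a methoxy group, a carboxylic acid or a longer chain ending in hydroxy would test this, and whether the step carries over to the fluoro analogue remains open.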